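Swapping a fluorophenyl for a fluoropyridine

The source may report more compounds than this note shows. Statements on the series, on what has been measured and on what is new or still open speak of the compounds shown alone.

- Compound 1 `COc1ccc(/C=C/C(=O)c2ccccc2-c2ccc(F)cc2)cc1` gives 53 nM
- Compound 2 `COc1ccc(/C=C/C(=O)c2ccccc2-c2ccc(F)cc2)cc1B(O)O` gives 21 nM
- Compound 3 `COc1ccc(/C=C/C(=O)c2ccccc2-c2cccc(F)c2)cc1` gives 73 nM

All three values come from a functional assay on CNE-2 cells (Homo sapiens) for antiproliferative activity, read by sulforhodamine B assay, with a stated time of 48 h (on this read-out lower numbers stand for stronger inhibition and higher numbers for weaker inhibition), and show how strongly each compound holds back the growth of these cells. Compound 3 gives 73 nM here, within the usual scatter of compound 1 at 53 nM. Compound 2 gives 21 nM, and the gap between compound 3 and compound 2 lies clearly beyond the scatter.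

The next compound is compound 4 `COc1ccc(/C=C/C(=O)c2ccccc2-c2ccc(F)nc2)cc1`, where 6-fluoropyridin-3-yl stands in place of 3-fluorophenyl: 6-fluoropyridin-3-yl in place of 3-fluorophenyl on an aromatic carbon. The closest evidence is a 1.4-fold higher number from compound 1 to compound 3 (0.14 log units; within the scatter), since that change also concerns the fluorine-bearing group. The other measured step, a 2.5-fold lower number from compound 1 to compound 2 (0.40 log units; beyond the scatter), leaves the 4-fluorophenyl group as it was and so says little here. For the measured compounds named here, no measured step exchanges a carbon-only ring for one holding nitrogen, so the direction remains uncertain and the range must stay wide.

Only a small drift towards a higher number is expected, not a step clearly beyond the scatter. The estimated step is a 1.2-fold higher number from compound 3 to compound 4 (0.09 log units; within the scatter) and no more than a cautious guess. Compound 4 is therefore estimated at 90 nM, with an expected range from 35 nM to 250 nM.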

Compound 4, half-maximal inhibitory concentration: 160 nM
Beside the measured number, compound 4's estimate is 1.8-fold (0.25 log units) below it, within the range that was stated.
By their numbers in this assay, from the lowest: compound 2; then compounds 1 and 3 (each within the scatter of the next); then compound 4.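

Among the compounds shown, only the exchange of a carbon-only ring for 6-fluoropyridin-3-yl moves the number beyond the scatter at this position: in this assay there is a 2.2-fold higher number from compound 3 to compound 4 (0.34 log units; beyond the scatter) and also a 3.0-fold higher number from compound 1 to compound 4 (0.48 log units; beyond the scatter), so inhibition is weaker against either fluorophenyl compound. Compounds 1 and 3 differ only in where the fluorine sits on the carbon-only ring, and their values stay within the scatter of each other, so a nitrogen in the ring matters more here than that shift of the fluorine. Nothing measured here gives a reason for this loss of activity.

The compounds shown leave open whether the loss follows from the ring nitrogen alone or also depends on the fluorine on that ring, a question that a ring with nitrogen but no fluorine could help to settle. They also leave open how a ring carrying an amine or a carboxylic acid would behave on this aromatic carbon, and whether the boron-bearing group of compound 2 would still lower the number when combined with 6-fluoropyridin-3-yl.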